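The source may hold more compounds than are shown below. What is called first, only, known or untested is meant among the compounds shown, and "the series" means these compounds.

Measured so far:
compound 1 `COc1cc(-c2ncnn2-c2cccc(F)c2)cc(OC)c1OC`: > 10000 nM (limit)
compound 2 `COc1cc(-c2ncnn2-c2ccc(Cl)cc2Cl)cc(OC)c1OC`: > 10000 nM (limit)

In a functional assay on MCF7 cells (Homo sapiens) for antiproliferative activity, read by MTT assay, with a stated time of 72 h (on this read-out higher numbers stand for weaker inhibition and lower numbers for stronger inhibition), compound 2 stands at > 10000 nM as a limit and not a number. Compound 1 rests at > 10000 nM and that too is a limit. Compound 3 `COc1cc(-c2ncnn2-c2cccc(N)c2)cc(OC)c1OC` differs from compound 2 by 3-aminophenyl in place of 2,4-dichlorophenyl on an aromatic nitrogen with 3-aminophenyl in place of 2,4-dichlorophenyl on an aromatic nitrogen. Within the data shown here, the one measured step that the two limits leave unreadable from compound 1 to compound 2 has no readable size and both values sit at the limit of > 10000 nM in this assay, at which 2 of the 2 values shown sit, so no step beyond the scatter is expected in this assay here. The expected step is a number no higher from compound 2 to compound 3 (the limit leaves the size open) by this estimate. For compound 3 the estimated value is 10000 nM with an expected range from 2500 nM to 30000 nM and a report as a limit is likely.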

Compound 3, half-maximal inhibitory concentration: > 10000 nM
Compound 3 was reported as a limit; the forecaster's own chance of this, stated with the estimate: 65%; the middle value sits exactly at the limit.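

In this assay no step can be read among compound 1, compound 2 and compound 3, as all three values are limits and not numbers. The compounds shown leave open how these three compare and whether any group on this aromatic nitrogen gives a measurable value.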